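Cyclohexyl for Methylbenzyl in an Amide Series at the Limit

The compounds below may be only part of what the source reports. "The series", "measured", "known", "first", "only" and "open" are said of these compounds alone.

Of the compounds shown here, three built on one shared core have been tested in a functional assay on A549 cells (Homo sapiens) for cytotoxicity, read by MTT assay, with a stated time of 24 h; on this read-out lower numbers stand for stronger inhibition and higher numbers for weaker inhibition. Compound 1 `C=CC1=C(C(=O)NCc2ccccc2)C(c2ccc(OC)c(OC)c2)OC1` gives only a limit of the assay there, > 100000 nM. Compound 3 `C=CC1=C(C(=O)Nc2ccccc2)C(c2ccc(OC)cc2)OC1` likewise returns only a limit, > 100000 nM. Compound 2 `C=CC1=C(C(=O)NCc2ccc(C)cc2)C(c2ccc(F)cc2)OC1`, the starting point of the step followed here, also sits at a limit, > 100000 nM. Among the measured compounds shown here, every value therefore rests at the limit of > 100000 nM in this assay, at which 3 of the 3 values shown sit, so no step between measured compounds can be read from these data, and compound 2 stands at the same limit as the others rather than at any number.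

Compound 4 `C=CC1=C(C(=O)NC2CCCCC2)C(c2ccc(F)cc2)OC1` has not yet been measured in this assay. It differs from compound 2 in one place: cyclohexyl in place of 4-methylbenzyl on an amide-type nitrogen. For the measured compounds named here, with every measured value at the same limit, there is no step from which the effect of this change could be gauged, and the step the estimate implies, a step that the limit leaves unreadable from compound 2 to compound 4, is expected to be none beyond the usual scatter. For compound 4 the expected result in this assay is 150000 nM, within 50000 nM to 500000 nM, most likely reported once more as a limit rather than a number.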

Compound 4, half-maximal inhibitory concentration: > 100000 nM
Compound 4: no number, only a limit; the forecaster's own chance of this, stated with the estimate: 85%; the middle value does not contradict the limit.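

Compound 2 and compound 4 both return only a limit, so no step can be read for cyclohexyl in place of 4-methylbenzyl: the limit of > 100000 nM in this assay, at which 4 of the 4 values shown sit.

The compounds shown leave open whether this amide change alters cytotoxicity at all, since none of them gives a number.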